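The source may report more compounds than this note shows. Statements on the series, on what has been measured and on what is new or still open speak of the compounds shown alone.

In a physicochemical assay for lipophilicity (on this read-out lower numbers stand for lower lipophilicity and higher numbers for higher lipophilicity), compound 1 `COc1ccc(C2=[N+]3C(=Nc4c(-c5ccccc5)c5c(n4[B-]3(F)F)-c3ccc(OCC(=O)O)cc3CC5)C(c3ccccc3)=C2I)cc1` gives 0.94 and compound 2 `COc1ccc(C2=[N+]3C(=Nc4c(-c5ccccc5)c5c(n4[B-]3(F)F)-c3ccc(OCC(=O)N[C@@H](CC(=O)O)C(=O)O)cc3CC5)C(c3ccccc3)=C2I)cc1` gives -0.77 as the lower of the two numbers. Compound 3 `COc1ccc(C2=[N+]3C(=Nc4c(-c5ccccc5)c5c(n4[B-]3(F)F)-c3ccc(OCC(=O)N[C@@H](CCC(=O)O)C(=O)O)cc3CC5)C(c3ccccc3)=C2I)cc1` differs from compound 2 by carboxymethyl in place of carboxy on a saturated chain carbon, two bonds along the chain from an amide-type nitrogen and a carbonyl carbon with carboxymethyl in place of carboxy on a saturated chain carbon, two bonds along the chain from an amide-type nitrogen and a carbonyl carbon. For the measured compounds named here, the only measured step, a number 1.71 log units lower from compound 1 to compound 2 (beyond the scatter) for a far larger change, (1,2-dicarboxyethyl)amino in place of hydroxy, bears only loosely on this one. A small step is therefore expected, a number 0.17 log units higher from compound 2 to compound 3 (within the scatter) in this assay and if anything upward. Compound 3 is estimated at -0.6 (expected range -1 to -0.2).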

Compound 3, partition coefficient: -0.74
Compound 3: the middle estimate sits 0.14 log units above what was measured; low and high end bracket the measured number.
By their numbers in this assay, from the lowest: compounds 2 and 3 (each within the scatter of the next); then compound 1.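

In this assay, carboxymethyl in place of carboxy on a saturated chain carbon, two bonds along the chain from an amide-type nitrogen and a carbonyl carbon, gives a number 0.03 log units higher from compound 2 to compound 3 (within the scatter), so this read-out does not separate the 1,2-dicarboxyethyl and 1,3-dicarboxypropyl side chains. Placing (1,3-dicarboxypropyl)amino on the carbonyl carbon instead of hydroxy gives a number 1.68 log units lower from compound 1 to compound 3 (beyond the scatter), a large step like that seen with (1,2-dicarboxyethyl)amino. Nothing available explains these results. On these data alone, what remains open is whether a longer chain carrying the same carboxy group, or an amine in its place, would keep the number in this range.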